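Trifluoromethyl on the benzyl ring of two thiazolidinedione cores

The source may hold more compounds than are shown below. What is called first, only, known or untested is meant among the compounds shown, and "the series" means these compounds.

Measured so far:
compound 1 `C=C(Br)C(=O)Nc1ccc(/C=C2\SC(=O)N(Cc3ccccc3)C2=O)cc1` gives 1100 nM in a functional assay on L1210 cells (Mus musculus) for cytotoxicity, read by cell counting, with a stated time of 2 days; on this read-out higher numbers stand for weaker inhibition and lower numbers for stronger inhibition;
compound 2 `C=C(Br)C(=O)Nc1ccc(/C=C2\SC(=O)N(Cc3ccc(C(F)(F)F)cc3)C2=O)cc1` gives 12000 nM in this assay;
compound 3 `Nc1cccc(/C=C2\SC(=O)N(Cc3ccccc3)C2=O)c1` gives 233000 nM in this assay.

Compound 1 and compound 2 share one core and differ in a single place: trifluoromethyl in place of hydrogen on an aromatic carbon. This change brought an 11-fold higher number from compound 1 to compound 2 (1.04 log units; beyond the scatter), so on the core of compound 1 the trifluoromethyl group went with a clearly weaker result.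

Compound 3 has a different core; the difference between the two cores is not broken down here. Among the three measured compounds compound 3 gives the highest number, and its gaps to compound 2 and to compound 1 both lie beyond the scatter of this assay.

Compound 4 `Nc1cccc(/C=C2\SC(=O)N(Cc3ccc(C(F)(F)F)cc3)C2=O)c1` is not yet measured. It stands to compound 3 as compound 2 stands to compound 1: trifluoromethyl in place of hydrogen on an aromatic carbon. The place of the change reads the same in both pairs, so this is the same change, now made on the core of compound 3.

On the core of compound 1 the change was measured as an 11-fold higher number from compound 1 to compound 2 (1.04 log units; beyond the scatter); the expectation for the core of compound 3 rests on that single step, and the step from compound 3 to compound 4 is expected to be a 6.4-fold higher number from compound 3 to compound 4 (0.81 log units; beyond the scatter). Compound 4 is therefore estimated to give about 1500000 nM in this assay, with a range from 400000 nM to 5000000 nM. Since compound 3 already gives 233000 nM, compound 4 would be expected to stand as the weakest of the four in this assay.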

Compound 4, half-maximal inhibitory concentration: > 250000 nM
Compound 4: a limit, no number (the forecaster's own chance of this, stated with the estimate: 35%); the middle value lies beyond the limit too.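

In this assay compound 4 gives > 250000 nM, which is a limit of the assay and not a number. On these data alone, on the second core, trifluoromethyl in place of hydrogen on an aromatic carbon can therefore be read only as a floor, an at least 1.0-fold higher number from compound 3 to compound 4 (0.03 log units; that floor lies within the scatter), and this floor alone neither shows a weaker result on that core nor rules one out, so the true size of the step stays unknown. The result shows that nothing here contradicts the change carrying over from one core to the other, but it does not show that the change carries over with the same size, or that its size depends on the core: the same change on two cores in this assay, an 11-fold higher number (1.04 log units; beyond the scatter) from compound 1 to compound 2 and an at least 1.0-fold higher number (0.03 log units; that floor lies within the scatter) from compound 3 to compound 4; the limit leaves it open whether they differ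

The compounds shown leave open how other groups in the same place, such as a chlorine atom, a methoxy group or a nitrile, would compare with trifluoromethyl on either core. They also leave open how trifluoromethyl would read on a core in which the amine of compound 3 gives way to an acetamide or a carboxylic acid, where a value might be obtained as a number rather than as a limit.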